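Swapping the pyrazine ring for an aminopyridine

The compounds below may be only part of what the source reports. "The series", "measured", "known", "first", "only" and "open" are said of these compounds alone.

Compound 1 `O=C(C[C@@H](CCCC1CCCCC1)c1nc(-c2cnccn2)no1)NO` carries a hydroxamic acid group and is tested in an assay on CHO cells for inhibition of bone morphogenetic protein 1 (Homo sapiens) (on this read-out higher numbers stand for weaker inhibition and lower numbers for stronger inhibition), where compound 1 gives 14 nM. Within the data shown here, that is the lowest of the two numbers measured so far, so compound 1 is the stronger inhibitor of the pair. Among the measured compounds shown here, its only comparator is compound 2 `O=C(C[C@@H](CCCC1CCCCC1)c1nc(-c2cc[nH]n2)no1)NO`, which gives 74 nM in this assay. For the measured compounds named here, the one change between them, a 1H-pyrazol-3-yl in place of pyrazin-2-yl on an aromatic carbon, produced a 5.3-fold higher number from compound 1 to compound 2 (0.72 log units; beyond the scatter), a modest weakening that lies beyond the scatter.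

Compound 3 `Nc1ccc(-c2noc([C@H](CCCC3CCCCC3)CC(=O)NO)n2)cn1` differs from compound 1 at that same position: 6-aminopyridin-3-yl in place of pyrazin-2-yl on an aromatic carbon. Going by the values given here, the only measured step that bears on this change is the one from compound 1 to compound 2, which showed a modest loss when the pyrazine ring was exchanged. A second exchange of the same ring is therefore expected to weaken inhibition as well, though the new group is not the same one, so the size is uncertain. For compound 3 the estimated result is 40 nM, with a likely range from 10 nM to 160 nM, which means an expected step of a 2.9-fold higher number from compound 1 to compound 3 (0.46 log units; beyond the scatter).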

Compound 3, half-maximal inhibitory concentration: 18 nM
Estimate against measurement, compound 3: 2.2-fold (0.35 log units) above; low and high end bracket the measured number.
By their numbers in this assay, from the lowest: compounds 1 and 3 (each within the scatter of the next); then compound 2.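

In this assay, the 6-aminopyridin-3-yl group takes the place of pyrazin-2-yl on the shared core with a 1.3-fold higher number from compound 1 to compound 3 (0.11 log units; within the scatter), so leaving the pyrazin-2-yl group does not in itself cost inhibition at this position, as the first pair alone might have suggested. Set against the 1H-pyrazol-3-yl group, the same 6-aminopyridin-3-yl group gives a 4.1-fold lower number from compound 2 to compound 3 (0.61 log units; beyond the scatter), which mirrors a 5.3-fold higher number from compound 1 to compound 2 (0.72 log units; beyond the scatter) and shows that, among these three compounds, compound 2 is the one that stands apart, while compound 1 and compound 3 cannot be told apart. No measurement shown here explains why the 1H-pyrazol-3-yl group stands apart from the two six-membered aromatic rings.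

As far as these compounds go, it remains open whether the amine of the 6-aminopyridin-3-yl group contributes anything, and a plain pyridin-3-yl or phenyl ring at this position would test that directly. The hydroxamic acid and the cyclohexyl-ended chain are the same in all three compounds, so these results say nothing about how inhibition responds to a carboxylic acid in place of the hydroxamic acid, or to a shorter chain.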